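Series notes: aryl substituent change from compound 2 to compound 3

A few compounds are considered here, and "the series" means these few. Any claim that something is new, unique, unknown or untested is made for them only; others in the source may bear on it.

Compound 2 `Cn1nc2c(=O)n(CC3(O)CCN(Cc4ccc(-c5ccco5)cc4Cl)CC3)cnc2c1-c1ccc(OC(F)F)cc1` stands lowest of the two numbers in an assay on isolated protein for inhibition of ubiquitin carboxyl-terminal hydrolase 7 (Homo sapiens), with stated times of 30 min and 2 h (a lower number here means a stronger inhibitor, a higher number a weaker inhibitor), where compound 2 gives 179 nM. Compound 1 `Cn1nc2c(=O)n(CC3(O)CCN(Cc4ccc(-c5ccco5)cc4Cl)CC3)cnc2c1-c1ccc(CNC(=O)C(F)(F)F)cc1` gives 2060 nM in this assay. Compound 3 `CCCNCc1ccc(-c2c3ncn(CC4(O)CCN(Cc5ccc(-c6ccco6)cc5Cl)CC4)c(=O)c3nn2C)cc1` carries (propylamino)methyl in place of difluoromethoxy on an aromatic carbon. Going by the values given here, the one step that bears on this change is a 12-fold lower number from compound 1 to compound 2 (1.06 log units; beyond the scatter), in which the (((trifluoromethyl)carbonyl)amino)methyl group gave the higher number; compound 3 again carries a substituted aminomethyl, now with a propyl chain in place of the acyl group. A weakening step is expected, a 3.1-fold higher number from compound 2 to compound 3 (0.49 log units; beyond the scatter), smaller than that one. Compound 3 is expected at 550 nM, with a range of 150 nM to 2000 nM.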

Compound 3, half-maximal inhibitory concentration: 43.9 nM
For compound 3 the middle estimate is 13-fold (1.10 log units) above the measured one; measured number outside the range, below it.
By their numbers in this assay, from the lowest: compound 3; then compound 2; then compound 1.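

At this aromatic carbon, para to a large group, (propylamino)methyl in place of difluoromethoxy gives a 4.1-fold lower number from compound 2 to compound 3 (0.61 log units; beyond the scatter) in this assay, so an aminomethyl substituent is compatible with the lowest number of the three compounds. On the amine nitrogen, propyl in place of (trifluoromethyl)carbonyl gives a 47-fold lower number from compound 1 to compound 3 (1.67 log units; beyond the scatter), which ties the high number of compound 1 to the acyl group, not to the aminomethyl link. No evidence at hand accounts for either step.

Open, on these data alone, is how much the propyl chain itself contributes. A primary amine, a butyl chain or a tertiary amine at this nitrogen would separate chain length from the amine hydrogen.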